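Thioether side chain exchange on a shared core

This account rests on a few compounds, and the source may have more. Where it says the series, first, only, none or still open, it means among the compounds named here.

Measured so far:
- compound 1, `Cc1cc(Nc2cc(-c3ccccc3)[nH]n2)n2nc(SCc3ccc(Br)cc3)nc2n1`, gives 39300 nM in an ADME assay on GES1 cells (Homo sapiens) for inhibition, read by MTT assay, with a stated time of 72 h; a higher number here means a weaker inhibitor, a lower number a stronger inhibitor
- compound 2, `Cc1cc(Nc2cc(-c3ccccc3)[nH]n2)n2nc(SCC(=O)c3ccccc3)nc2n1`, gives 33300 nM in this assay

Going by the values given here, compound 2 holds the lowest of the two numbers, but its only neighbour is compound 1, and the step of a 1.2-fold lower number from compound 1 to compound 2 (0.07 log units; within the scatter) is within the scatter, so the two compounds are not separated on these data.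

Compound 3, `Cc1cc(Nc2cc(-c3ccccc3)[nH]n2)n2nc(SCc3ccccc3Br)nc2n1`, has not yet been measured. Relative to compound 2 the change is 2-bromophenyl in place of benzoyl on a saturated chain carbon bound to a sulfur. Among the compounds with values here, the one measured step that bears on this exchange is a 1.2-fold lower number from compound 1 to compound 2 (0.07 log units; within the scatter), which swapped a 4-bromophenyl for a benzoyl at the same place and did not move the number beyond the scatter. Compound 3 brings a bromine-bearing phenyl back onto that chain carbon, as in compound 1, with the bromine in a different position. Nothing measured here suggests a step beyond the scatter, so no direction is assigned; the expected step is a 1.1-fold higher number from compound 2 to compound 3 (0.03 log units; within the scatter). Compound 3 is estimated at 36000 nM, with a range from 15000 nM to 85000 nM.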

Compound 3, half-maximal inhibitory concentration: 41100 nM
For compound 3 the middle estimate is 1.1-fold (0.06 log units) below the measured one; the range from low to high includes it.
By their numbers in this assay, from the lowest: compounds 2, 1 and 3 (each within the scatter of the next).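

In this assay, exchanging benzoyl for 2-bromophenyl gives a 1.2-fold higher number from compound 2 to compound 3 (0.09 log units; within the scatter), so a second exchange at this place also stays within the scatter. The series now also has a comparison of two bromine placements on the same phenyl group: 2-bromophenyl in place of 4-bromophenyl gives a 1.0-fold higher number from compound 1 to compound 3 (0.02 log units; within the scatter), and this change does not separate the two compounds. With benzoyl, 4-bromophenyl and 2-bromophenyl all within the scatter of one another, these three compounds show no detectable effect of the exchange at this place, and nothing available here accounts for that result.

On these data alone, all three side chains still end in a six-membered aromatic ring of carbon only, so it remains open whether a primary amine, a carboxylic acid or a longer saturated carbon chain at this place would give a step beyond the scatter. As far as these compounds go, it is also open whether the same insensitivity would hold with a different substituent elsewhere on the shared core.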